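The compounds below may be only part of what the source reports. "The series", "measured", "known", "first", "only" and "open" are said of these compounds alone.

Measured compounds:
Compound 1, `Cc1ccc(-n2cc(-c3ccccc3NS(=O)(=O)c3c[nH]c(=O)[nH]c3=O)nn2)cc1`: in a functional assay on OVCAR-3 cells (Homo sapiens) for antiproliferative activity, read by MTT assay, with a stated time of 24 h (a higher number here means a weaker inhibitor, a lower number a stronger inhibitor), compound 1 gives 2190 nM.
Compound 2, `O=c1[nH]cc(S(=O)(=O)Nc2ccccc2-c2cn(-c3ccc(Cl)cc3)nn2)c(=O)[nH]1`: in this assay compound 2 gives 1750 nM.
Compound 3, `O=c1[nH]cc(S(=O)(=O)Nc2cccc(-c3cn(-c4ccccc4)nn3)c2)c(=O)[nH]1`: in this assay compound 3 gives only a limit, > 20000 nM, which is a boundary of the assay and not a number.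

Compounds 1 and 2 carry the same core and differ only in one group on the outer ring; the step of a 1.3-fold lower number from compound 1 to compound 2 (0.10 log units; within the scatter) shows that this exchange left the result essentially unchanged. On these data alone, compound 3 stands apart from both: its value sits at the limit of > 20000 nM in this assay, at which 1 of the 3 values shown sits, so its true position is unknown and can only be said to lie somewhere past that boundary.

Compound 4, `Cc1ccccc1-n1cc(-c2cccc(NS(=O)(=O)c3c[nH]c(=O)[nH]c3=O)c2)nn1`, differs from compound 3 by methyl in place of hydrogen on an aromatic carbon. Among the compounds with values here, no measured pair shows this exact change, and the one measured step, from compound 1 to compound 2, concerns a different group at a different place on the ring and stayed within the scatter. Nothing here therefore points to a large shift, and the expected step that the limit leaves unreadable from compound 3 to compound 4 is small. Compound 4 is thus expected to give about 25000 nM in this assay, with a plausible range from 8000 nM to 80000 nM, and most likely again only a limit.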

Compound 4, half-maximal inhibitory concentration: 6230 nM
Beside the measured number, compound 4's estimate is 4.0-fold (0.60 log units) above it, and the stated range ends above it.
By their numbers in this assay, from the lowest: compounds 2 and 1 (each within the scatter of the next); then compound 4. At a limit, above all of these: compound 3.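

In this assay the change from phenyl to 2-methylphenyl gives an at least 3.2-fold lower number from compound 3 to compound 4 (0.50 log units; beyond the scatter) and so moves the compound from a limit of the assay to a number that can be read. Within the data shown here, one added methyl, ortho to a large group on the outer ring, is therefore enough to produce a step beyond the scatter, whereas the only earlier step, a 1.3-fold lower number from compound 1 to compound 2 (0.10 log units; within the scatter), exchanged one group for another on the outer ring of a different pair and left the result essentially unchanged. The true size of the new step cannot be given and only its smallest possible size is known, because compound 3 sits at a limit and not at a number: the limit of > 20000 nM in this assay, at which 1 of the 4 values shown sits.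

The compounds shown do not tell why the methyl has this effect, or whether it depends on the methyl itself or would also appear with another group in the same place, such as an ethyl chain, a chloro, an amine or a carboxylic acid. They also leave open whether a methyl elsewhere on this outer ring would give a similar step.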